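Swapping a pyridin-2-yl onto the pyrrolidine of compound 2

A few compounds are considered here, and "the series" means these few. Any claim that something is new, unique, unknown or untested is made for them only; others in the source may bear on it.

Of the compounds shown here, three built on a shared core have been measured in an assay on isolated protein for inhibition of Rho-associated protein kinase 2 (Homo sapiens), read by a luciferase reporter; a lower number here means a stronger inhibitor, a higher number a weaker inhibitor. Compound 1 `Cc1cccc(C2CNCC2C(=O)Nc2cc3cc[nH]c(=O)c3cc2Cl)c1` gives 5 nM. Compound 2 `CC(C)c1cccc(C2CNCC2C(=O)Nc2cc3cc[nH]c(=O)c3cc2Cl)c1`, which carries isopropyl in place of methyl on an aromatic carbon, gives 6 nM. Compound 3 `O=C(Nc1cc2cc[nH]c(=O)c2cc1Cl)C1(c2ccccc2)CCNC1`, whose phenyl sits on a different ring carbon together with the amide, gives 240 nM.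

Compound 2 stands second highest of the three numbers: compound 1 sits closest, with a 1.2-fold higher number from compound 1 to compound 2 (0.08 log units; within the scatter), while compound 3, with 240 nM, sits furthest.

The next compound, compound 4 `O=C(Nc1cc2cc[nH]c(=O)c2cc1Cl)C1CNCC1c1ccccn1`, differs from compound 2 as follows: pyridin-2-yl in place of 3-isopropylphenyl on a saturated ring carbon. Going by the values given here, only one measured step bears on this change, the one from compound 1 to compound 2, and it stayed within the scatter, so the aryl substituent seems to matter little between methyl and isopropyl. Among the compounds with values here, no measured compound, however, shows what a pyridin-2-yl without any substituent does in this position. Compound 3 offers no guide here; its change lies elsewhere.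

The expectation for compound 4 is therefore a modest weakening, a 2.5-fold higher number from compound 2 to compound 4 (0.40 log units; beyond the scatter), with wide uncertainty. Compound 4 is estimated at 15 nM, with a range from 4 nM to 60 nM.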

Compound 4, half-maximal inhibitory concentration: 14 nM
Estimate against measurement, compound 4: 1.1-fold (0.03 log units) above; low and high end bracket the measured number.
By their numbers in this assay, from the lowest: compounds 1 and 2 (each within the scatter of the next); then compound 4; then compound 3.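

In this assay, this saturated ring carbon proves to accept a change of the whole aryl group and not only of its alkyl substituent, at a modest cost: pyridin-2-yl in place of 3-isopropylphenyl gives a 2.3-fold higher number from compound 2 to compound 4 (0.37 log units; beyond the scatter), and pyridin-2-yl in place of 3-methylphenyl gives a 2.8-fold higher number from compound 1 to compound 4 (0.45 log units; beyond the scatter). The earlier step had varied only methyl against isopropyl on a phenyl ring, whereas this one replaces a carbon-only aromatic ring of 9 heavy atoms with a ring of 6 heavy atoms that holds 1 nitrogen and 1 hydrogen-bond acceptor, and the number still stays well short of that of compound 3 at 240 nM. Nothing available explains the modest loss that comes with this change.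

The step joins two changes, the ring nitrogen and the loss of the alkyl group, and the compounds shown do not separate them; plain phenyl on this same carbon, or a pyridin-2-yl carrying methyl or isopropyl, would pull them apart. Also open, on these data alone, is how pyridin-3-yl, or a phenyl ring bearing an amine or a carboxylic acid, would read at this carbon.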